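Bromo for cyclohexyl at the cytotoxicity limit

This account rests on a few compounds, and the source may have more. Where it says the series, first, only, none or still open, it means among the compounds named here.

In an ADME assay on Vero cells (Chlorocebus sabaeus) for cytotoxicity, read by resazurin assay, with a stated time of 72 h (on this read-out higher numbers stand for lower toxicity in this test and lower numbers for higher toxicity in this test), compound 1 (`O=C(/C=C/c1ccc([N+](=O)[O-])o1)c1ccc(-n2ccnc2)cc1`) gives > 100000 nM as a limit and not a number. Compound 2 (`O=C(/C=C/c1ccc([N+](=O)[O-])o1)c1ccc(C2CCCCC2)cc1`) likewise gives only a limit, > 100000 nM in the same test. Going by the values given here, the one measured step (a step that the two limits leave unreadable from compound 1 to compound 2) has no readable size, and the evidence is a shared limit (the limit of > 100000 nM in this assay, at which 2 of the 2 values shown sit). Compound 3 (`O=C(/C=C/c1ccc([N+](=O)[O-])o1)c1ccc(Br)cc1`) carries a single change from compound 2 (bromo in place of cyclohexyl on an aromatic carbon), bromo in place of cyclohexyl on an aromatic carbon. Among the compounds with values here, no measured step gives a size or direction for this, so no step beyond the scatter is expected in this assay for this change. The expected step (an at least 1.1-fold lower number from compound 2 to compound 3 (0.04 log units; that floor lies within the scatter)) is an estimate only. For compound 3 the estimated value is 90000 nM (expected range 30000 nM to 200000 nM), and another limit is quite likely.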

Compound 3, half-maximal cytotoxic concentration: > 100000 nM
Compound 3 gave a limit, no number; the forecaster's own chance of this, stated with the estimate: 65%; at least 1.1-fold (0.04 log units) between middle value and limit.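

In this assay, going by these compounds alone, compound 3 gives a limit, not a number, so no step among compound 1, compound 2 and compound 3 can be read: the limit of > 100000 nM in this assay, at which 3 of the 3 values shown sit. The compounds shown leave open whether cyclohexyl, bromo or 1H-imidazol-1-yl differ at all in their half-maximal cytotoxic concentration.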